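This account rests on a few compounds, and the source may have more. Where it says the series, first, only, none or still open, it means among the compounds named here.

In a functional assay on SW620/5-FU cells (Homo sapiens) for cytotoxicity, read by MTT assay, with a stated time of 48 h, in the presence of a further agent that is not named here (on this read-out lower numbers stand for an effect already at smaller amounts and higher numbers for an effect only at larger amounts of compound), compound 1 `COc1ccc(-c2cc(NNC(=O)Nc3cc(Cl)nc(Cl)c3)nc3c2cnn3C)cc1` gives 18500 nM as its value. Compound 2 `COc1ccc(-c2cc(NNC(=O)Nc3cc(Cl)nc(Cl)c3)nc3c2c(C)nn3C)cc1` gives 9700 nM as its value, which places it level with compound 1, since the two numbers lie within the usual scatter of each other and cannot be ranked. Compound 3 `Cc1nn(C)c2nc(NNC(=O)Nc3cc(Cl)nc(Cl)c3)cc(-c3ccccc3)c12` keeps the frame of compound 2 and changes one group, with hydrogen in place of methoxy on an aromatic carbon as the counted difference: hydrogen in place of methoxy on an aromatic carbon, so that 4-methoxyphenyl becomes phenyl. Among the compounds with values here, no measured pair shows this change directly. Within the data shown here, the only measured step, a 1.9-fold lower number from compound 1 to compound 2 (0.28 log units; within the scatter) for methyl in place of hydrogen on an aromatic carbon, concerns another group and bears on this one only loosely, as a sign of how little the numbers have moved so far. With nothing measured on the methoxy itself, no step beyond the scatter is expected in this assay and no direction can be favoured. The estimate amounts to a 1.0-fold higher number from compound 2 to compound 3 (0.01 log units; within the scatter) as the expected step. Compound 3 is estimated at 10000 nM with an expected range from 4000 nM to 25000 nM in this measurement.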

Compound 3, half-maximal effective concentration: 22900 nM
Compound 3: middle estimate off by 2.3-fold (0.36 log units), on the low side; the measured number falls inside the stated range.
By their numbers in this assay, from the lowest: compounds 2, 1 and 3 (each within the scatter of the next, the first and the last beyond it).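

In this assay, going from 4-methoxyphenyl to phenyl gives a 2.4-fold higher number from compound 2 to compound 3 (0.37 log units; beyond the scatter), a modest step but the first one here that lies beyond the scatter. Within the data shown here, this shows that the number does respond to what sits on this aromatic carbon, para to a large group, whereas the methyl step between the earlier compounds could not be told apart from the scatter, and that the compound with methoxy in this place is the one needing the smaller amount. The result rests on a single pair, and nothing at hand explains why the number moves with this group.

The compounds shown leave open whether the methoxy itself matters or whether another group in its place, such as an ethoxy, a hydroxyl, an amine or a fluorine, would give the same number, a lower one or a higher one. They also leave open whether the same change would give a step of similar size on the core of compound 1, which lacks the added methyl.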